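The compounds below may be only part of what the source reports. "The series", "measured", "known", "first", "only" and "open" are said of these compounds alone.

Measured so far:
compound 1, `CC(C)n1c(/C=C2/C(=O)Nc3ccc(Br)cc32)nc2ccccc21`, in a functional assay on PC-3 cells (Homo sapiens) for cytotoxicity, read by MTT assay, with a stated time of 48 h (on this read-out lower numbers stand for stronger inhibition and higher numbers for weaker inhibition), compound 1 gives 10700 nM.
compound 2, `CCn1c(/C=C2/C(=O)Nc3ccccc32)nc2ccccc21`, in this assay compound 2 gives 38000 nM.

Compound 2 holds the higher of the two numbers, and its gap to compound 1 lies beyond the scatter. Compound 1 differs from compound 2 in more than one place, so that gap cannot be tied to a single change. Compound 3, `CC(C)n1c(/C=C2/C(=O)Nc3ccccc32)nc2ccccc21`, differs from compound 2 only by methyl in place of hydrogen on a saturated chain carbon bound to an aromatic nitrogen and a saturated chain carbon. Going by the values given here, no measured pair isolates this change, so the step in this assay is expected to be small, if anything toward a lower number. Compound 3 is estimated at 25000 nM, within 8000 nM to 70000 nM, a step of a 1.5-fold lower number from compound 2 to compound 3 (0.18 log units; within the scatter).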

Compound 3, half-maximal inhibitory concentration: 37600 nM
The estimate for compound 3 lay 1.5-fold (0.18 log units) below the measured number; the range from low to high includes it.
By their numbers in this assay, from the lowest: compound 1; then compounds 3 and 2 (each within the scatter of the next).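

Going from ethyl to isopropyl gives a 1.0-fold lower number from compound 2 to compound 3 (0.00 log units; within the scatter), so the added methyl makes no readable difference in this assay. The bromo on an aromatic carbon counts for more: hydrogen in its place gives a 3.5-fold higher number from compound 1 to compound 3 (0.55 log units; beyond the scatter). Nothing available here explains either step.

The compounds shown leave open whether a longer chain such as butyl on that aromatic nitrogen, or chloro or methoxy in place of bromo, would shift the number. Also open, going by these compounds, is whether bromo would give a similar step alongside ethyl instead of isopropyl.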